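The source may hold more compounds than are shown below. What is called first, only, known or untested is meant among the compounds shown, and "the series" means these compounds.

Measured compounds:
Compound 1 `Cc1nc(C)c(Cn2ncc3c(Nc4ccc(OC(F)(F)F)cc4)ncnc32)s1`. In an ADME assay on BaF3 cells (Mus musculus) for cytotoxicity (a lower number here means that less compound is needed, a higher number that more compound is needed for the effect), compound 1 gives > 10000 nM, which is a limit of the assay.
Compound 2 `FC(F)(F)Oc1ccc(Nc2cc(-c3ccncc3)ncn2)cc1`. In this assay compound 2 gives > 10000 nM, again a limit.
Compound 3 `FC(F)(F)Oc1ccc(Nc2ncnc3c2cnn3CC2CCOC2)cc1`. In this assay compound 3 gives > 10000 nM, also a limit.

Among the measured compounds shown here, compound 3 thus stands where every value in the set stands: all three sit at the limit of > 10000 nM in this assay, at which 3 of the 3 values shown sit, and no compound of the series has a numerical read-out. For the measured compounds named here, the only single-point change between measured compounds, a step that the two limits leave unreadable from compound 1 to compound 3, cannot be sized, since both of its ends are limits. Compound 2 differs from compound 3 in more than one place and gives no further foothold.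

The next compound, compound 4 `FC(F)(F)Oc1ccc(Nc2ncnc3c2cnn3Cc2ccccc2)cc1`, is not yet measured. (phenyl in place of oxolan-3-yl on a saturated chain carbon bound to an aromatic nitrogen). Going by the values given here, the one measured step, a step that the two limits leave unreadable from compound 1 to compound 3, touches the same place but is unreadable, so nothing measured tells how this change acts in this assay.

Given that all three measured values sit at the limit, the expectation for compound 4 is that it stays there too, and the expected step that the limit leaves unreadable from compound 3 to compound 4 is none beyond the scatter. The estimate for compound 4 in this assay is 15000 nM, with a range from 5000 nM to 50000 nM, and most likely the assay will again report only a limit.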

Compound 4, half-maximal effective concentration: > 10000 nM
Compound 4 ended at the assay's limit; the forecaster's own chance of this, stated with the estimate: 80%; the middle value lies beyond the limit too.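

In this assay compound 4 gives > 10000 nM, again a limit of the assay. Neither step to it, from compound 1 or from compound 3, can be read. Left open is whether any group on the saturated chain carbon bound to an aromatic nitrogen shifts the read-out, with every compound shown at one position: the limit of > 10000 nM in this assay, at which 4 of the 4 values shown sit.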